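This account rests on a few compounds, and the source may have more. Where it says the series, first, only, none or still open, it means among the compounds named here.

Measured compounds in a functional assay on U-937 cells (Homo sapiens) for cytotoxicity, read by CCK-8 assay, with a stated time of 72 h; a lower number here means a stronger inhibitor, a higher number a weaker inhibitor:
- compound 1 `COc1ccccc1/C=c1/[nH]c(=O)/c(=C\c2ccccc2OC)n(C)c1=O` gives 1500 nM
- compound 2 `C=CCn1c(=O)/c(=C\c2cc(Br)ccc2F)[nH]c(=O)/c1=C\c1ccccc1OC` gives 4700 nM
- compound 3 `C=CCn1c(=O)/c(=C\c2cccc(Br)c2)[nH]c(=O)/c1=C\c1cccc(Br)c1` is reported as "not active" (no number reported)

Compound 2 holds the higher of the two reported numbers in this assay. Its nearest neighbour is compound 1, whose number is lower by a gap beyond the scatter. Compound 3 is reported only as not active, with no number to place it.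

Compound 4 `C=CCn1c(=O)/c(=C\c2cccc(C)c2)[nH]c(=O)/c1=C\c1ccccc1OC` is not yet measured. It differs from compound 2 by 3-methylphenyl in place of 5-bromo-2-fluorophenyl on a double-bonded chain carbon bound to an aromatic carbon. For the measured compounds named here, no pair of measured compounds differs in this position alone, so no measured step shows what this change does. Compound 2 and compound 3 show that a bromine-bearing ring at this position is compatible with a high number or with no measurable activity, while compound 1 shows that the lower number came with a different pattern of rings. On this basis the change is expected to move the number by no more than the scatter, in no firm direction, so the expected step of a 1.1-fold higher number from compound 2 to compound 4 (0.03 log units; within the scatter) is small. Compound 4 is expected to give 5000 nM, within a range of 1500 nM to 20000 nM.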

Compound 4, half-maximal inhibitory concentration: 5100 nM
The estimate for compound 4 lay 1.0-fold (0.01 log units) below the measured number, within the range that was stated.
By their numbers in this assay, from the lowest: compound 1; then compounds 2 and 4 (each within the scatter of the next).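

In this assay, for the compounds shown here, 3-methylphenyl in place of 5-bromo-2-fluorophenyl gives a 1.1-fold higher number from compound 2 to compound 4 (0.04 log units; within the scatter), the first step that can be read at this position. Both the bromine and the fluorine leave in this change, so for this pair on the shared core, neither halogen is needed to keep the number at this level. Nothing available bears on why the step is this small.

From the compounds shown here alone, the effect of an amine or a carboxylic acid on this aromatic ring remains open, and this single step does not show whether other ring substituents would behave in the same way. Also open, going by these compounds, is whether the aromatic ring is needed at all, or whether a longer chain could stand on this double-bonded chain carbon without moving the number beyond the scatter.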